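Working notes: replacing the pyridine group with cyclohexyl

This account rests on a few compounds, and the source may have more. Where it says the series, first, only, none or still open, it means among the compounds named here.

Measured in a functional assay on NFS-60 cells (Mus musculus) for inhibition, with a stated time of 72 h; on this read-out higher numbers stand for weaker inhibition of growth and lower numbers for stronger inhibition of growth:
compound 1 `Nc1ncnc2c(C(=O)Nc3cccc4c3c(Br)nn4Cc3ccncc3)csc12` gives 135 nM
compound 2 `Nc1ncnc2c(C(=O)Nc3cccc4c3c(Br)nn4Cc3cccc(F)n3)csc12` gives 233 nM
compound 3 `Cc1cccc(Cn2nc(Br)c3c(NC(=O)c4csc5c(N)ncnc45)cccc32)n1` gives 27.5 nM

Compound 3 holds the lowest number of the three, at 27.5 nM, and its gaps to both others lie beyond the scatter. The next change puts cyclohexyl in place of 6-methylpyridin-2-yl on a saturated chain carbon bound to an aromatic nitrogen, giving compound 4 `Nc1ncnc2c(C(=O)Nc3cccc4c3c(Br)nn4CC3CCCCC3)csc12`: cyclohexyl in place of 6-methylpyridin-2-yl on a saturated chain carbon bound to an aromatic nitrogen.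

Among the measured compounds shown here, the steps at this same place are the only guide. The data show a 4.9-fold lower number from compound 1 to compound 3 (0.69 log units; beyond the scatter) and an 8.5-fold lower number from compound 2 to compound 3 (0.93 log units; beyond the scatter), both modest, whereas a 1.7-fold higher number from compound 1 to compound 2 (0.24 log units; within the scatter) stays within the scatter. All three measured groups are pyridine-based, and no saturated ring has been measured here, so the estimate is uncertain. For the measured compounds named here, since compound 3 has the lowest number so far, a modest step toward a higher number in this assay is expected, of about the size of those two steps. The estimate means a 5.1-fold higher number from compound 3 to compound 4 (0.71 log units; beyond the scatter). For compound 4 the expected value is 140 nM, with an estimated range of 35 nM to 560 nM.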

Compound 4, concentration for 50% growth inhibition: 254 nM
Compound 4: middle estimate off by 1.8-fold (0.26 log units), on the low side; low and high end bracket the measured number.
By their numbers in this assay, from the lowest: compound 3; then compounds 1, 2 and 4 (each within the scatter of the next).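

In this assay, the advantage of 6-methylpyridin-2-yl does not carry over to the saturated ring, with a 9.2-fold higher number from compound 3 to compound 4 (0.97 log units; beyond the scatter). Cyclohexyl, with no hydrogen-bond acceptor, stays within the scatter of the other two pyridine groups, at a 1.1-fold higher number from compound 2 to compound 4 (0.04 log units; within the scatter) and a 1.9-fold higher number from compound 1 to compound 4 (0.27 log units; within the scatter), so a pyridine ring alone confers no advantage here and, among these four, only compound 3 stands apart. No supporting data explain why compound 3 stands apart.

Still open, as far as these compounds go, is how phenyl, an aromatic ring of carbon only, or piperidin-4-yl, a saturated ring holding an amine, would read at this place. Also open, from the compounds shown here alone, is whether a methyl on the cyclohexyl ring would bring the number down towards that of compound 3.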